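A few compounds are considered here, and "the series" means these few. Any claim that something is new, unique, unknown or untested is made for them only; others in the source may bear on it.

Measured so far:
Compound 1 `Cc1nc2c(OCc3ccccc3)cccn2c1C#N` — 25%
Compound 2 `[C-]#[N+]Cc1c(C)nc2c(OCc3ccccc3)cccn12` — 96%

In a functional assay on the whole organism with Rattus norvegicus as the target, with a stated time of 4 h, at a dose of 40 mg/kg by the intraperitoneal route (a higher number here means more inhibition at the dose given (going by the name of the read-out), a lower number less inhibition), compound 1 gives 25%, the lower of the two numbers seen; compound 2 gives 96%, and the step of a number 71 percentage points higher from compound 1 to compound 2 (beyond the scatter) is the only one measured so far.

Compound 3 `Cc1nc2c(OCc3ccccc3)cccn2c1CS(C)(=O)=O` is the compound not yet tested. It differs from compound 1 in one place: (methylsulfonyl)methyl in place of cyano on an aromatic carbon.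

Going by the values given here, the one measured step that bears on this change is the step from compound 1 to compound 2, in which the cyano was also replaced by a longer non-ring group attached through a carbon, and the read-out in this assay rose sharply. Among the compounds with values here, the group entering in compound 3 is different from the one entering in compound 2, so that step is only a rough guide, and with a single comparison no firm pattern can be claimed. Still, it points toward an increase rather than a fall.

Compound 3 is therefore expected to give about 60% in this assay, within a range from 25% to 95%, a step of a number 35 percentage points higher from compound 1 to compound 3 (beyond the scatter) relative to compound 1.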

Compound 3, a percentage reported as inhibition, in the whole organism at one dose (the size of the read-out at that dose, not a potency): 61%
Estimate against measurement, compound 3: 1 percentage points below, and the stated range covers the measured number.
By their numbers in this assay, from the lowest: compound 1; then compound 3; then compound 2.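

In this assay the swap of cyano for (methylsulfonyl)methyl on the aromatic carbon gives a number 36 percentage points higher from compound 1 to compound 3 (beyond the scatter) and so shows that the rise seen with compound 2 is not unique to the group of that compound. Compound 2 and compound 3 share a saturated chain carbon bound to the aromatic carbon, yet the change on that carbon gives a number 35 percentage points lower from compound 2 to compound 3 (beyond the scatter) and shows that what this carbon carries also matters. Among these three compounds, both groups attached through that carbon give higher numbers than cyano, with no compound going against this, but three compounds are too few to support a general rule for this position.

From the compounds shown here alone, it remains open how an amine, a carboxylic acid or a longer chain on the same saturated chain carbon would compare with the groups of compound 2 and compound 3. Nothing given here explains why these groups differ in this whole-animal test.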